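The compounds below may be only part of what the source reports. "The series", "measured", "known", "first", "only" and "open" are said of these compounds alone.

Compound 1 `CCOC(=O)C(=O)Nc1cccccc1=O` gives 84% in a functional assay on the whole organism (strain Sprague-Dawley CD) for inhibition, with Rattus norvegicus as the target, read by paw edema, at a dose of 30 mg/kg by the intraperitoneal route; a higher number here means a stronger effect of the compound at the dose given, a lower number a weaker effect; compound 2 `CCOC(=O)C(=O)Nc1ccc(OC)ccc1=O` gives 8%; compound 3 `CCOC(=O)C(=O)Nc1cccc(OC)cc1=O` gives 67%.

Compound 2 stands lowest of the three in this assay, well beyond the scatter below both compound 1 and compound 3. Compound 4 `CCOC(=O)C(=O)Nc1ccc(NC(=O)C(=O)OCC)c(=O)cc1` differs from compound 2 by ((ethoxycarbonyl)carbonyl)amino in place of methoxy on an aromatic carbon. Among the measured compounds shown here, two steps bear on this: a number 76 percentage points lower from compound 1 to compound 2 (beyond the scatter), where the same methoxy entered, and a number 17 percentage points lower from compound 1 to compound 3 (beyond the scatter), also an entering methoxy. For the measured compounds named here, neither step covers the entering group, so its own effect is unknown; the only guide is that the methoxy leaves. A rise in this assay is expected, a number 37 percentage points higher from compound 2 to compound 4 (beyond the scatter), with wide uncertainty. Compound 4 is estimated at 45%, range 10% to 85%.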

Compound 4, a percentage reported as inhibition, in the whole organism at one dose (the size of the read-out at that dose, not a potency): 84%
Compound 4: the middle estimate sits 39 percentage points below what was measured; the measured number falls inside the stated range.
By their numbers in this assay, from the lowest: compound 2; then compound 3; then compounds 1 and 4 (each within the scatter of the next).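

At this position, three ring bonds from the ring atom that bears a group of 8 heavy atoms, the outcome depends on the group: ((ethoxycarbonyl)carbonyl)amino in place of methoxy gives a number 76 percentage points higher from compound 2 to compound 4 (beyond the scatter) in this assay. Against hydrogen, the same group gives no change at the digits printed from compound 1 to compound 4 (within the scatter), so substitution here need not cost effect at this dose, with compound 2 the case against. Nothing on hand explains the difference between the two groups. Still open, going by these compounds, is which part of the entering group matters: a plain amine or a free carboxylic acid at this position would help separate them.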